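The source may report more compounds than this note shows. Statements on the series, on what has been measured and on what is new or still open speak of the compounds shown alone.

Working notes on the series. Compound 2 `COc1cc(C(=O)N2CCC(O)C(C)C2)cc2nc(NCc3cccc(Cl)c3)oc12` gives 25 nM in an assay on isolated protein for inhibition of thyroid hormone receptor beta (Homo sapiens), read by fluorescence, with a stated time of 30 min (a higher number here means a weaker inhibitor, a lower number a stronger inhibitor), the lowest of the three numbers measured; compound 1 `COc1cc(C(=O)N2CCC(O)CC2)cc2nc(NCc3cccc(Cl)c3)oc12` gives 352 nM and compound 3 `COc1cc(C(=O)N2CCC(O)C(C)C2)cc2nc(NCc3cccc(Cl)n3)oc12` gives 580 nM in this assay. The two measured steps are a 14-fold lower number from compound 1 to compound 2 (1.15 log units; beyond the scatter) and a 23-fold higher number from compound 2 to compound 3 (1.37 log units; beyond the scatter). Compound 4 `COc1cc(C(=O)N2CC(C)C(O)CC2CCO)cc2nc(NCc3cccc(Cl)c3)oc12` differs from compound 2 by 2-hydroxyethyl in place of hydrogen on a saturated ring carbon. For the measured compounds named here, neither measured step changes this position; only the step from compound 1 to compound 2 touches the same ring, and it shows that a single added group there can move this assay by a large amount, in either direction as far as the data tell. Going by the values given here, with no direct precedent, the expected step is a 1.6-fold higher number from compound 2 to compound 4 (0.20 log units; within the scatter), within the scatter but with a wide range. Compound 4 is thus expected to give 40 nM in this assay, between 8 nM and 250 nM.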

Compound 4, half-maximal inhibitory concentration: 0.27 nM
The estimate for compound 4 lay 150-fold (2.17 log units) above the measured number, outside the stated range (below it).
By their numbers in this assay, from the lowest: compound 4; then compound 2; then compounds 1 and 3 (each within the scatter of the next).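

In this assay, for the compounds shown here, 2-hydroxyethyl on the saturated ring carbon next to the ring nitrogen gives a 93-fold lower number from compound 2 to compound 4 (1.97 log units; beyond the scatter) and is the only measured change at this position, so this carbon can carry a group with a large move towards a lower number. The full change on the carbonyl carbon gives a 1300-fold lower number from compound 1 to compound 4 (3.12 log units; beyond the scatter) in the same direction. Nothing available explains the size of this step. As far as these compounds go, it remains open whether the chain's hydroxy group is needed, as a 2-aminoethyl, ethyl or 3-hydroxypropyl group would show. Also open, from the compounds shown here alone, is whether 2-hydroxyethyl has the same effect with 6-chloropyridin-2-yl in place of 3-chlorophenyl.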